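The compounds below may be only part of what the source reports. "The series", "measured", "known", "first", "only" and "open" are said of these compounds alone.

Working notes on the series. In a functional assay on ZR-75-1 cells (Homo sapiens) for cytotoxicity, read by sulforhodamine B assay, with a stated time of 3 days (on this read-out lower numbers stand for an effect already at smaller amounts and higher numbers for an effect only at larger amounts of compound), compound 1 (`CCOCc1c(C)coc1-c1ccc2c(c1OC)CCCC2(C)C`) gives 19.8 uM. Compound 2 (`CCOc1c(-c2occ(C)c2CO)ccc2c1CCCC2(C)C`) gives 14.3 uM. Within the data shown here, these two numbers lie within the usual scatter of each other, so compound 1 cannot be separated from the only other measured member. Compound 3 (`COCc1c(C)coc1-c1ccc2c(c1OC)CCCC2(C)C`) has not yet been measured in this assay. Its difference from compound 1 is hydrogen in place of methyl on a saturated chain carbon bound to an oxygen on a saturated carbon, which reads as ethoxymethyl to methoxymethyl. Among the measured compounds shown here, no measured pair shows this change, so the series offers no step to lean on, and no shift beyond the scatter is expected in either direction. The expected step, a 1.1-fold lower number from compound 1 to compound 3 (0.04 log units; within the scatter), is estimated to stay within the scatter. For compound 3 the expected value is 18 uM, with an estimated range of 9 uM to 35 uM.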

Compound 3, concentration for half-maximal effect: 14.3 uM
The estimate for compound 3 lay 1.3-fold (0.10 log units) above the measured number, within the range that was stated.
By their numbers in this assay, from the lowest: compounds 2, 3 and 1 (each within the scatter of the next).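

In this assay, this position now has its first measured step, a 1.4-fold lower number from compound 1 to compound 3 (0.14 log units; within the scatter), so ethoxymethyl to methoxymethyl does not separate the two compounds. Hydrogen in place of methyl on a saturated chain carbon bound to an oxygen on a saturated carbon therefore leaves the read-out within the scatter, and on this single pair the ethyl and methyl forms of the ether count as equivalent. No supporting data bear on what lies behind this result.

From the compounds shown here alone, whether a longer chain such as propoxymethyl, or a group of another kind such as an amine or a carboxylic acid, would shift the number beyond the scatter at this position remains open. Also open, going by these compounds, is whether the same change would give a similar step on a core other than that of compound 1.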